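Acyl variation on the proline-linked sulfonamide piperidines

The source may report more compounds than this note shows. Statements on the series, on what has been measured and on what is new or still open speak of the compounds shown alone.

Measured so far, in an assay on isolated protein for binding affinity to secreted frizzled-related protein 1 (Homo sapiens), read by fluorescence; a higher number here means a weaker inhibitor, a lower number a stronger inhibitor:
compound 1 `O=C(CN1CCCC1)N1CCC(NS(=O)(=O)c2cc(S(=O)(=O)c3ccccc3)ccc2C(F)(F)F)CC1` gives 110 nM
compound 2 `O=C(CN1CCNCC1)N1CCC(NS(=O)(=O)c2cc(S(=O)(=O)c3ccccc3)ccc2C(F)(F)F)CC1` gives 140 nM
compound 3 `CC(C)(C)CC(=O)N1CCC[C@H]1C(=O)N1CCC(NS(=O)(=O)c2cc(S(=O)(=O)c3ccccc3)ccc2C(F)(F)F)CC1` gives 20 nM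

Compound 3 stands at the lowest number of the three: the steps of a 5.5-fold lower number from compound 1 to compound 3 (0.74 log units; beyond the scatter) and a 7.0-fold lower number from compound 2 to compound 3 (0.85 log units; beyond the scatter) both lie beyond the scatter, while a 1.3-fold higher number from compound 1 to compound 2 (0.10 log units; within the scatter) lies within it. Compound 4 `O=C([C@@H]1CCCN1C(=O)N1CCOCC1)N1CCC(NS(=O)(=O)c2cc(S(=O)(=O)c3ccccc3)ccc2C(F)(F)F)CC1` differs from compound 3 by morpholin-4-yl in place of neopentyl on a carbonyl carbon. Among the compounds with values here, no measured pair bears directly on this exchange; the two informative steps only show that the 1-(neopentylcarbonyl)pyrrolidin-2-yl unit of compound 3 outperforms the simpler tails of compound 1 and compound 2, and compound 4 retains the pyrrolidin-2-yl amide while altering only the group on its carbonyl carbon. Lacking a precedent, the step is expected to be a 1.8-fold higher number from compound 3 to compound 4 (0.24 log units; within the scatter), not clearly beyond the scatter in either direction. Compound 4 is therefore estimated at 35 nM in this assay, with a range of 12 nM to 110 nM.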

Compound 4, half-maximal inhibitory concentration: 40 nM
Compound 4: the middle estimate sits 1.1-fold (0.06 log units) below what was measured; the measured number falls inside the stated range.
By their numbers in this assay, from the lowest: compounds 3 and 4 (each within the scatter of the next); then compounds 1 and 2 (each within the scatter of the next).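

In this assay the exchange of neopentyl for morpholin-4-yl on a carbonyl carbon gives a 2.0-fold higher number from compound 3 to compound 4 (0.30 log units; within the scatter) and so does not separate the two compounds. Within the data shown here, this is the first reading at this carbonyl carbon: an open all-carbon group and a six-membered non-aromatic ring with 2 hetero atoms read alike here. No measurement on hand explains this result.

Still open, on these data alone, is how a primary amine, a carboxylic acid or a chain longer than neopentyl would read on this carbonyl carbon. As far as these compounds go, whether a ring without oxygen, such as piperidin-1-yl, reads like morpholin-4-yl here also remains unknown.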